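Hydrazone aryl swap in a shared-core antiproliferative series

This account rests on a few compounds, and the source may have more. Where it says the series, first, only, none or still open, it means among the compounds named here.

Measured so far:
compound 1 `CCCSc1nc(N/N=C(\C)c2ccccc2O)c2nnn(Cc3ccc(Cl)cc3)c2n1`: 7100 nM
compound 2 `CCCSc1nc(N/N=C/c2ccccc2Cl)c2nnn(Cc3ccccc3)c2n1`: 10900 nM

In a functional assay on MGC-803 cells (Homo sapiens) for antiproliferative activity, read by MTT assay, with a stated time of 72 h (on this read-out higher numbers stand for weaker inhibition and lower numbers for stronger inhibition), compound 1 gives 7100 nM, and compound 2 gives 10900 nM. Compound 2 holds the higher of the two numbers, but its gap to compound 1 lies within the scatter, so the two compounds cannot be ordered. They also differ from each other in more than one place, so no single change has yet been isolated in this assay.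

Compound 3 `CCCSc1nc(N/N=C/c2c(O)ccc3ccccc23)c2nnn(Cc3ccccc3)c2n1` differs from compound 2 in one place: 2-hydroxynaphthalen-1-yl in place of 2-chlorophenyl on a carbon with a double bond to nitrogen. For the measured compounds named here, no measured pair shows this change, so there is no reference step. Both measured compounds sit in the same region of this assay, and nothing seen so far points to a large move in either direction. The step from compound 2 to compound 3 is therefore expected to be small, a 1.7-fold lower number from compound 2 to compound 3 (0.22 log units; within the scatter), at most near the edge of the scatter. Compound 3 is estimated at 6500 nM, with a range from 2000 nM to 20000 nM.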

Compound 3, half-maximal inhibitory concentration: 3710 nM
Estimate against measurement, compound 3: 1.8-fold (0.24 log units) above; measured number inside the range.
By their numbers in this assay, from the lowest: compounds 3, 1 and 2 (each within the scatter of the next, the first and the last beyond it).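

For the compounds shown here, at the carbon with a double bond to nitrogen, a single change can now be read for the first time: in this assay, 2-hydroxynaphthalen-1-yl in place of 2-chlorophenyl gives a 2.9-fold lower number from compound 2 to compound 3 (0.47 log units; beyond the scatter). The aryl group at this place therefore affects the read-out, and the larger group with two aromatic rings brings no loss here. The change removes chlorine, adds a hydroxyl group and adds a second aromatic ring all at once, and no measurement at hand bears on why the number moves.

Open, from the compounds shown here alone, is which part of the swap carries the step, a question that plain naphthalen-1-yl or 2-hydroxyphenyl on the same core would address. Also open, going by these compounds, are an amine or a carboxylic acid at this place, and whether the step holds with the other groups of compound 1.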